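Series notes: acyl chain extension on the shared core

A few compounds are considered here, and "the series" means these few. Any claim that something is new, unique, unknown or untested is made for them only; others in the source may bear on it.

Within the data shown here, compound 2 `CC(=O)N1N=C(c2ccc(-n3ccnc3)cc2)CC1c1ccc(N(C)C)cc1` and compound 1 `CN(C)c1ccc(C2CC(c3ccc(-n4cncn4)cc3)=NN2C(=O)CCCl)cc1` are the two measured members. In a functional assay on NCI-H1975 cells (Homo sapiens) for inhibition, read by sulforhodamine B assay, tested at 10 uM (a higher number here means more inhibition at the concentration tested (going by the name of the read-out), a lower number less inhibition), compound 2 gives -2.1%, numerically the smaller of the two measured values but within the scatter of compound 1, which gives -0.7% in this assay. Neither compound shows inhibition of any visible degree at the concentration tested, and nothing separates them.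

Compound 3 `CN(C)c1ccc(C2CC(c3ccc(-n4ccnc4)cc3)=NN2C(=O)CCCl)cc1` has not yet been measured. It differs from compound 2 as follows: chloromethyl in place of hydrogen on a saturated chain carbon bound to a carbonyl carbon. Among the measured compounds shown here, no step between measured compounds is available on which to rest a direction, and both measured values sit close to zero. The expected step in this assay is a number 2.1 percentage points higher from compound 2 to compound 3 (within the scatter), that is none beyond the scatter. Compound 3 is therefore estimated at 0% in this assay, with a range from -10% to 12%.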

Compound 3, a percentage reported as inhibition, at one concentration (the size of the read-out at that concentration, not a potency): -2.5%
For compound 3 the middle estimate is 2.5 percentage points above the measured one; the range from low to high includes it.
By their numbers in this assay, from the lowest: compounds 3, 2 and 1 (each within the scatter of the next).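

Working notes: in this assay, chloromethyl in place of hydrogen on a saturated chain carbon bound to a carbonyl carbon gives a number 0.4 percentage points lower from compound 2 to compound 3 (within the scatter), so with the 1H-imidazol-1-yl group held constant, the change from acetyl to (2-chloroethyl)carbonyl does not separate the two compounds. Among these compounds, the first comparison at the aromatic carbon, 1H-imidazol-1-yl in place of 1H-1,2,4-triazol-1-yl, gives a number 1.8 percentage points lower from compound 1 to compound 3 (within the scatter), so that exchange does not separate its pair either. No supporting measurement bears on either result.

With no inhibition visible in any of the three compounds, neither step shows whether these two places can influence this read-out at all. Going by these compounds, whether an amine or a longer chain in place of the 2-chloroethyl group would give measurable inhibition remains open.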